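The source may hold more compounds than are shown below. What is called first, only, known or untested is meant among the compounds shown, and "the series" means these compounds.

Measured so far:
compound 1 `CC(C)(C)CC(=O)N1C[C@H](OCC(=O)NC[C@H](NC(=O)C2(C)CCCCC2)C(=O)O)C[C@H]1CNc1ccccn1` — 1.4 nM
compound 2 `Cc1cc(C)c(S(=O)(=O)N[C@@H](CNC(=O)CO[C@@H]2C[C@@H](CNc3ccccn3)N(C(=O)OCc3ccccc3)C2)C(=O)O)c(C)c1` — 3.7 nM

Both numbers come from an assay on a protein complex for inhibition of integrin alpha-5/beta-1 (Homo sapiens), read by ELISA; on this read-out higher numbers stand for weaker inhibition and lower numbers for stronger inhibition. Compound 1 has the lowest of the two numbers; compound 2 gives a higher one, and the gap is beyond the usual scatter, so compound 1 is the stronger inhibitor of the pair. Compound 3 `Cc1cc(C)c(C(=O)N[C@@H](CNC(=O)CO[C@@H]2C[C@@H](CNc3ccccn3)N(C(=O)CC(C)(C)C)C2)C(=O)O)c(C)c1` has not yet been measured. It differs from compound 1 in one place: 2,4,6-trimethylphenyl in place of 1-methylcyclohexyl on a carbonyl carbon. Among the measured compounds shown here, no measured pair shows this change, so only a small step is expected, a 1.8-fold higher number from compound 1 to compound 3 (0.25 log units; within the scatter), towards a slightly higher number. Compound 3 is estimated at 2.5 nM, with a range from 0.8 nM to 8 nM.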

Compound 3, half-maximal inhibitory concentration: 1.6 nM
Estimate against measurement, compound 3: 1.6-fold (0.19 log units) above, within the range that was stated.
By their numbers in this assay, from the lowest: compounds 1 and 3 (each within the scatter of the next); then compound 2.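

In this assay, putting 2,4,6-trimethylphenyl in place of 1-methylcyclohexyl on a carbonyl carbon gives a 1.1-fold higher number from compound 1 to compound 3 (0.06 log units; within the scatter), so the change makes no readable difference. Among the compounds shown here, this is the first pair that differs at this position alone, and it shows that an aromatic carbon ring and a non-aromatic one with fewer heavy atoms can both sit here with values within the scatter of each other. Nothing available explains this result. Still open, going by these compounds, is how a smaller group such as tert-butyl would read at this position, and whether a ring carrying an amine would do the same.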